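The compounds below may be only part of what the source reports. "The series", "measured", "known", "first", "only" and "open" are said of these compounds alone.

Among the compounds with values here, in a functional assay on RAW264.7 cells (Mus musculus) for inhibition, with stated times of 1 h and 24 h (a lower number here means a stronger inhibitor, a higher number a weaker inhibitor), compound 2 (`COc1ccccc1C(=O)Nc1cccc(-c2cc(=O)c3c(O)c(OC)c(OC)cc3o2)c1`) gives 310 nM as the only number available, so there is no other compound to rank it against. Compound 1 (`COc1ccccc1C(=O)Nc1cccc(-c2cc(=O)c3c(OC)c(OC)c(OC)cc3o2)c1`) offers no number, its result standing as "not determined" (no result reported) in the record. Compound 3 (`COc1ccccc1NC(=O)c1cccc(-c2cc(=O)c3c(O)c(OC)c(OC)cc3o2)c1`) has the same atoms as compound 2, joined differently: (2-methoxyphenyl)carbamoyl in place of ((2-methoxyphenyl)carbonyl)amino on an aromatic carbon, meta to a large group ((2-methoxyphenyl)carbamoyl in place of ((2-methoxyphenyl)carbonyl)amino on an aromatic carbon). Within the data shown here, no measured step between related compounds is available to guide the size of this change in this assay, so only a modest weakening, not far beyond the usual scatter, is expected, and the estimated step of a 1.6-fold higher number from compound 2 to compound 3 (0.21 log units; within the scatter) stands for that view. In this assay compound 3 is estimated at 500 nM with an expected range from 170 nM to 1500 nM around that figure.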

Compound 3, half-maximal inhibitory concentration: 2380 nM
Compound 3: the middle estimate sits 4.8-fold (0.68 log units) below what was measured; measured number above the stated range.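

Reversing the amide link, with the same atoms at the same place on the aromatic ring, is not a neutral swap in this assay, where the change is a 7.7-fold higher number from compound 2 to compound 3 (0.89 log units; beyond the scatter) and lies beyond the usual scatter. The direction of this link therefore matters here: the ((2-methoxyphenyl)carbonyl)amino form of compound 2 is the stronger inhibitor of the pair, and the (2-methoxyphenyl)carbamoyl form of compound 3 the weaker. No measurement at hand accounts for the difference.

As far as these compounds go, whether the same order would hold with an amine or a carboxylic acid in place of the methoxy group on the 2-methoxyphenyl ring stays open, as this is a single pair. With compound 1 standing as "not determined" (no result reported) in this assay, the step between it and compound 2 on the shared core cannot be read.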